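Bergamide-type ester series: aromatic versus cycloalkyl ester

A few compounds are considered here, and "the series" means these few. Any claim that something is new, unique, unknown or untested is made for them only; others in the source may bear on it.

Measured compounds:
compound 1, `CCCCCCCCCCOc1ccc(C(=O)O[C@@H]2CCC(NC(=O)[C@H](OC)[C@H](O)[C@@H](O)[C@H](O)/C=C/C(C)(C)C)C(=O)NC2)cc1`, 10 nM
compound 2, `CO[C@@H](C(=O)NC1CC[C@@H](OC(=O)c2ccccc2)CNC1=O)[C@H](O)[C@@H](O)[C@H](O)/C=C/C(C)(C)C`, 370 nM
compound 3, `CCCCCCCCCCc1ccc(C(=O)O[C@@H]2CCC(NC(=O)[C@H](OC)[C@H](O)[C@@H](O)[C@H](O)/C=C/C(C)(C)C)C(=O)NC2)cc1`, 30 nM

In an in vivo functional assay on the whole organism (MDA-MB-435 cells, Homo sapiens) for antiproliferative activity (on this read-out higher numbers stand for weaker inhibition and lower numbers for stronger inhibition), compound 2 stands highest of the three, with a 12-fold lower number from compound 2 to compound 3 (1.09 log units; beyond the scatter) and a 37-fold higher number from compound 1 to compound 2 (1.57 log units; beyond the scatter) separating it from the others. Compound 4, `CO[C@@H](C(=O)NC1CC[C@@H](OC(=O)C2CCCCCC2)CNC1=O)[C@H](O)[C@@H](O)[C@H](O)/C=C/C(C)(C)C`, differs from compound 2 by cycloheptyl in place of phenyl on a carbonyl carbon. Among the compounds with values here, no measured step covers this exchange: the known steps, a 37-fold higher number from compound 1 to compound 2 (1.57 log units; beyond the scatter) and a 12-fold lower number from compound 2 to compound 3 (1.09 log units; beyond the scatter), both concern a long chain on the aromatic ring, and a 3.0-fold higher number from compound 1 to compound 3 (0.48 log units; beyond the scatter) concerns the link of that chain. They indicate only that the unsubstituted benzoate of compound 2 gave the weakest number. Compound 4 is therefore expected to change little, with a 1.2-fold lower number from compound 2 to compound 4 (0.09 log units; within the scatter). Compound 4 is estimated at 300 nM, in the range 90 nM to 1000 nM.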

Compound 4, half-maximal inhibitory concentration: 20 nM
Beside the measured number, compound 4's estimate is 15-fold (1.18 log units) above it, and the stated range ends above it.
By their numbers in this assay, from the lowest: compounds 1, 4 and 3 (each within the scatter of the next, the first and the last beyond it); then compound 2.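

In this assay, the step of a 19-fold lower number from compound 2 to compound 4 (1.27 log units; beyond the scatter) shows that the group on the carbonyl carbon can shift the number without any long chain on an aromatic ring. The earlier steps shown here varied only the decyl and decyloxy substituents on the benzoate, so they did not test replacing the phenyl itself. No measurement shown accounts for this shift. On these data alone, it remains open whether cyclohexyl, cyclooctyl or an open-chain decyl group would behave like cycloheptyl on this carbonyl carbon, and whether a decyl chain on the cycloheptyl ring would lower the number further.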